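This account rests on a few compounds, and the source may have more. Where it says the series, first, only, none or still open, it means among the compounds named here.

Of the compounds shown here, three sharing one core have been measured in an assay on isolated protein for inhibition of G protein-coupled receptor kinase 5 (Homo sapiens), read by TR-FRET, with stated times of 10 min and 1 h; a higher number here means a weaker inhibitor, a lower number a stronger inhibitor. Compound 1 `Nc1ncc(-c2cnn(C3CCNCC3)c2)cc1-c1nc2ccc(Nc3cc(C(F)(F)F)cc(C(F)(F)F)c3)cc2o1` gives 4200 nM. Compound 2 `Nc1ncc(-c2cnn(C3CCNCC3)c2)cc1-c1nc2ccc(OCc3ccccc3)cc2o1` gives 6900 nM. Compound 3 `Nc1ncc(-c2cnn(C3CCNCC3)c2)cc1-c1nc2ccc(-c3ccc4[nH]ncc4c3)cc2o1` gives 1140 nM, the lowest of the three numbers, with compound 1 the nearest to it and compound 2 the furthest, both gaps beyond the scatter. Among the measured compounds shown here, the only single-point step among them, a 6.1-fold lower number from compound 2 to compound 3 (0.78 log units; beyond the scatter), shows that exchanging the benzyloxy group for the indazolyl group made a modest but real gain.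

Compound 4 `COc1ccc(C(=O)Nc2ccc3nc(-c4cc(-c5cnn(C6CCNCC6)c5)cnc4N)oc3c2)cc1` is the next compound. It differs from compound 3 by ((4-methoxyphenyl)carbonyl)amino in place of 1H-indazol-5-yl on an aromatic carbon. For the measured compounds named here, no measured step exchanges the indazolyl group for an amide-linked aryl group, so nothing bears on this change directly. What the numbers do show is that compound 3 carries the indazolyl group and stands lowest, while compound 1 and compound 2, which carry other aryl-bearing groups at that carbon, stand higher. Removing the indazolyl group is therefore expected to raise the number toward the range of compound 1 and compound 2, and the step of a 3.1-fold higher number from compound 3 to compound 4 (0.49 log units; beyond the scatter) is the expected size. Compound 4 is estimated at 3500 nM, within a range from 1200 nM to 10000 nM.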

Compound 4, half-maximal inhibitory concentration: 2090 nM
For compound 4 the middle estimate is 1.7-fold (0.22 log units) above the measured one, and the stated range covers the measured number.
By their numbers in this assay, from the lowest: compounds 3, 4, 1 and 2 (each within the scatter of the next, the first and the last beyond it).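

In this assay, the change of 1H-indazol-5-yl to ((4-methoxyphenyl)carbonyl)amino gives a 1.8-fold higher number from compound 3 to compound 4 (0.26 log units; within the scatter) so the two groups cannot be told apart at this aromatic carbon, and the lowest number is no longer tied to the indazolyl group alone. The same position also separates ((4-methoxyphenyl)carbonyl)amino from benzyloxy, with a 3.3-fold lower number from compound 2 to compound 4 (0.52 log units; beyond the scatter) so two quite different groups, one a fused aromatic pair of rings and the other a single carbon-only aromatic ring joined through a carbonyl and amino link, now both stand clear of benzyloxy. Nothing available explains why these groups compare as they do.

The compounds shown leave open whether the gain over benzyloxy rests on the carbonyl and amino link, on the aromatic ring, or on the methoxy group that ring carries. They also do not tell how an unsubstituted benzoyl amide, a simple amine or a carboxylic acid at this carbon would compare, or whether any group there can move the number beyond the scatter from compound 3.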